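The source may report more compounds than this note shows. Statements on the series, on what has been measured and on what is new or still open speak of the compounds shown alone.

Measured compounds:
compound 1, `O=C(CSc1nnc(-c2ccccc2)n1-c1ccccc1)c1ccccc1`, 53%
compound 2, `CCn1c(SC/C(=N/O)c2ccccc2)nnc1-c1ccc(OC)c(OC)c1`, 61%
compound 3, `COc1ccc(-c2nnc(SCC(=O)c3ccccc3)n2-c2ccccc2)cc1`, 52%

All three were tested in a functional assay on the whole organism (strain albino) for inhibition, with Rattus norvegicus as the target, read by paw edema, with a stated time of 1 h, at a dose of 0.28 mmol/kg by the oral route; on this read-out higher numbers stand for more inhibition at the one dose given (going by the name of the read-out) and lower numbers for less inhibition. Compound 1 gives 53%, compound 3 gives 52%, and compound 2 gives 61%. The gaps between compound 2 and each of the other two are within the scatter, so none of the three stands apart from the others on this read-out. Compound 3 and compound 1 differ in one place: hydrogen in place of methoxy on an aromatic carbon. That change gives a number 1 percentage points higher from compound 3 to compound 1 (within the scatter), a step within the scatter. Compound 2 and compound 3 differ in more than one place, and the difference between the two cores is not broken down here.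

Compound 4, `CCn1c(SC/C(=N/O)c2ccccc2)nnc1-c1ccc(OC)cc1`, has not yet been measured in this assay. It arises from compound 2 by the same kind of change as that from compound 3 to compound 1: hydrogen in place of methoxy on an aromatic carbon. The surroundings are not identical: in compound 3 the methoxy that leaves is para to a large group, whereas in compound 2 it is ortho to a methoxy group and meta to a large group. Because the earlier step was a number 1 percentage points higher from compound 3 to compound 1 (within the scatter), the expected step is a number 1 percentage points lower from compound 2 to compound 4 (within the scatter), and this expectation rests on that one measured step alone. Compound 4 is estimated to give 60%, with an expected range from 48% to 71%.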

Compound 4, a percentage reported as inhibition, in the whole organism at one dose (the size of the read-out at that dose, not a potency): 69%
Compound 4: middle estimate off by 9 percentage points, on the low side, and the stated range covers the measured number.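

In this assay, hydrogen in place of methoxy on the six-membered aromatic ring gives a number 8 percentage points higher from compound 2 to compound 4 (within the scatter), so this step stays inside the usual variation of the read-out. Set beside the earlier step of the same kind, it does not differ from it beyond the scatter: the same change on two cores in this assay, a number 1 percentage points higher (within the scatter) from compound 3 to compound 1 and a number 8 percentage points higher (within the scatter) from compound 2 to compound 4, 7 percentage points apart, within the scatter of two such steps

Across these two cores, then, the change leaves the inhibition of paw edema within the scatter at this one dose, but with only one pair on each core, and with the methoxy leaving different surroundings in the two pairs, this does not show that the change would behave the same way on any further core in the series.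

The compounds shown have only methoxy or hydrogen at these places on the aromatic ring, so it remains open whether a chloro group, an amine or a carboxylic acid there would shift the inhibition beyond the scatter. On these data alone, it also remains open whether the two steps would stay this small at another dose or at a time other than the single one given.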